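Aryl swap on the aromatic nitrogen: compound 2 to compound 3

The compounds below may be only part of what the source reports. "The series", "measured", "known", "first", "only" and "open" are said of these compounds alone.

Compound 1 `COc1cc2c(Nc3cc(C(F)(F)F)ccc3F)ncnc2c(OC)c1OC`: 10300 nM
Compound 2 `COc1cc2c(Nc3cccc(Br)c3F)ncnc2c(OC)c1OC`: > 30000 nM

Both numbers come from a functional assay on SGC-7901 cells (Homo sapiens) for antiproliferative activity, read by MTT assay, with a stated time of 72 h; a higher number here means a weaker inhibitor, a lower number a stronger inhibitor. Compound 2 sits at the assay limit, > 30000 nM, so only a bound is known for it (the limit of > 30000 nM in this assay, at which 1 of the 2 values shown sits). Compound 1 gives a number, 10300 nM.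

Compound 3 `COc1cc2c(Nc3cc(F)ccc3Br)ncnc2c(OC)c1OC` differs from compound 2 by 2-bromo-5-fluorophenyl in place of 3-bromo-2-fluorophenyl on a nitrogen on an aromatic ring. For the measured compounds named here, no measured step covers this change. Since compound 2 is only a limit, compound 3 is expected to stay weak, and the expected step is a number no higher from compound 2 to compound 3 (the limit leaves the size open), none beyond the scatter. Compound 3 is therefore estimated at 30000 nM, within 8000 nM to 100000 nM.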

Compound 3, half-maximal inhibitory concentration: 18400 nM
Compound 3: middle estimate off by 1.6-fold (0.21 log units), on the high side; the range from low to high includes it.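

Rearranging the same atoms on the aryl group, 2-bromo-5-fluorophenyl in place of 3-bromo-2-fluorophenyl, gives an at least 1.6-fold lower number from compound 2 to compound 3 (0.21 log units; that floor lies within the scatter) in this assay. For the compounds shown here, this is the first step that can be read, and it changes only how the bromine and fluorine are placed on the ring. The step is only a floor because the value of compound 2 is a limit: the limit of > 30000 nM in this assay, at which 1 of the 3 values shown sits.

The compounds shown carry only halogen or trifluoromethyl on the phenyl ring. From the compounds shown here alone, how an amine or a carboxylic acid on that ring would read remains open.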